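The source may hold more compounds than are shown below. What is called first, only, known or untested is meant among the compounds shown, and "the series" means these compounds.

Measured so far in a functional assay on SNU-16 cells (Homo sapiens) for antiproliferative activity, read by CCK-8 assay, with a stated time of 72 h; on this read-out higher numbers stand for weaker inhibition and lower numbers for stronger inhibition:

- compound 1 `COc1ccc(F)c(-c2ccc3c(NC(=O)c4ccc(N(C)CCN(C)C)cc4)n[nH]c3c2)c1F` gives 366 nM.
- compound 2 `CCN1CCN(c2ccc(C(=O)Nc3n[nH]c4cc(-c5c(F)cc(F)c(OC)c5F)ccc34)cc2)CC1` returns only a limit of the assay, > 1000 nM.
- compound 3 `CCN1CCN(c2ccc(C(=O)Nc3n[nH]c4cc(-c5cccc(OC)c5F)cc(F)c34)cc2)CC1` likewise returns only a limit of the assay, > 1000 nM.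

Compound 1 is thus the one entry in this assay with a real number; the other two entries are limits, (the limit of > 1000 nM in this assay, at which 2 of the 3 values shown sit). Compound 4 `COc1ccc(F)c(-c2ccc3c(NC(=O)c4ccc(N5CCN(C(C)=O)CC5)cc4)n[nH]c3c2)c1F` has not yet been run in this assay. It differs from compound 1 in a single place: 4-acetylpiperazin-1-yl in place of (2-(dimethylamino)ethyl)(methyl)amino on an aromatic carbon. For the measured compounds named here, no pair of measured compounds differing in one place is available, so the size of this step cannot be read from the data and has to be estimated. Compounds 2 and 3 carry a different amine on the benzamide together with other changes to the core substitution and sit at the limit, so they do not isolate the effect of the amine exchange.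

The expectation is a step toward weaker inhibition, somewhat beyond the usual scatter but not necessarily reaching the limit. In this assay compound 4 is expected to give 750 nM, with a range from 250 nM to 2500 nM. The estimated step is a 2.0-fold higher number from compound 1 to compound 4 (0.31 log units; beyond the scatter), in the direction of weaker inhibition.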

Compound 4, half-maximal inhibitory concentration: 322 nM
The estimate for compound 4 lay 2.3-fold (0.37 log units) above the measured number, and the stated range covers the measured number.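

In this assay the exchange at this position gives a 1.1-fold lower number from compound 1 to compound 4 (0.06 log units; within the scatter), so the pair shows no readable change between the two groups. The aromatic carbon para to a large group therefore carries either the open (2-(dimethylamino)ethyl)(methyl)amino chain or 4-acetylpiperazin-1-yl, with its six-membered non-aromatic ring and its double bond outside aromatic rings, with no difference beyond the scatter; this holds for this one pair and this core only. Compounds 2 and 3 each return only a limit of the assay, not a number, and neither differs from compound 1 or compound 4 in one place alone, so steps to them cannot be read: the limit of > 1000 nM in this assay, at which 2 of the 4 values shown sit.

A single pair cannot separate the contribution of the piperazine ring from that of its acetyl group, and it cannot show whether the match in values extends to other groups at this place. A piperazine with a free ring amine, a 4-methylpiperazin-1-yl group or a morpholine ring at the same carbon would divide the change into smaller parts.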